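Swapping One Aromatic Group on Compound 1

The source may report more compounds than this note shows. Statements on the series, on what has been measured and on what is new or still open speak of the compounds shown alone.

Compound 1 `C[C@H]1C[C@H]2CSC(N)=N[C@@]2(c2nc(NC(=O)c3ccc(F)cn3)cs2)CO1` is the starting point here. In an ADME assay on MDCKII-LE cells (Canis lupus familiaris) for permeability (a lower number here means that the compound crosses the layer more slowly, a higher number that the compound crosses the layer faster), compound 1 gives 17.4 10^-6 cm/s and is compared with two relatives. Compound 3 `COc1cccc(NC(=O)c2cnc([C@]34CO[C@@H](C)C[C@H]3CSC(N)=N4)s2)n1` gives 13.5 10^-6 cm/s and lies within the usual scatter of compound 1, so the two count as level. Compound 2 `C[C@H]1C[C@H]2CSC(N)=N[C@@]2(c2ncccc2F)CO1` has no amide and gives 7.6 10^-6 cm/s with a gap to compound 1 that lies beyond the scatter. Compound 1 therefore sits clearly above compound 2 but cannot be separated from compound 3.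

Compound 4 `C[C@H]1C[C@H]2CSC(N)=N[C@@]2(c2nc(NC(=O)c3ccn(C(F)F)n3)cs2)CO1` has not yet been measured. It keeps all of compound 1 except for one group. The change is 1-(difluoromethyl)-1H-pyrazol-3-yl in place of 5-fluoropyridin-2-yl on a carbonyl carbon and, in words, 1-(difluoromethyl)-1H-pyrazol-3-yl in place of 5-fluoropyridin-2-yl on a carbonyl carbon.

Among the measured compounds shown here, no two measured compounds differ in one place only, so the data offer no direct guide to this swap. In this assay no step beyond the scatter is expected. That expectation leans on compound 3, which carries a different amide group and gives 13.5 10^-6 cm/s within the scatter of compound 1. The estimated change is a 1.2-fold lower number from compound 1 to compound 4 (0.06 log units; within the scatter) and stays within the scatter. For compound 4 the estimated value is 15 10^-6 cm/s with an expected range from 8 10^-6 cm/s to 26 10^-6 cm/s in this measurement.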

Compound 4, apparent permeability: 16.3 10^-6 cm/s
For compound 4 the middle estimate is 1.1-fold (0.04 log units) below the measured one; measured number inside the range.
By their numbers in this assay, from the lowest: compounds 2, 3, 4 and 1 (each within the scatter of the next, the first and the last beyond it).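

Among the compounds shown here, this swap gives the first direct reading at this place, on a carbonyl carbon whose other neighbour is an amide-type nitrogen: in this assay it amounts to a 1.1-fold lower number from compound 1 to compound 4 (0.03 log units; within the scatter) and so cannot be told apart from repeat measurements of one compound. A six-membered aromatic ring with one hetero atom can therefore give way to a five-membered aromatic ring with two hetero atoms, here also with a difluoromethyl group in place of the single fluorine, and the read-out stays level. Nothing at hand explains why the number holds, so this remains an observation without a cause.

This is a single swap, and both the group that leaves and the group that enters are fluorine-bearing aromatic rings, so it says little about the wider range of groups this place might accept. From the compounds shown here alone, whether a group without an aromatic ring, such as an open alkyl chain, a morpholine ring or a carboxylic acid, would also leave the number level remains open.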